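Replacing Ethyl with Hydroxy on the Shared Core

This account rests on a few compounds, and the source may have more. Where it says the series, first, only, none or still open, it means among the compounds named here.

Compound 1 `CCC1(O)CS(=O)(=O)c2cc(C(=O)N=C(N)N)c(C)cc21`: 77 nM
Compound 2 `Cc1cc2c(cc1C(=O)N=C(N)N)S(=O)(=O)C(C)(C)C2(C)O`: 102 nM
Compound 3 `CCC1CS(=O)(=O)c2cc(C(=O)N=C(N)N)c(C)cc21`: 78 nM

In a functional assay for inhibition, with Homo sapiens as the target (on this read-out higher numbers stand for weaker inhibition and lower numbers for stronger inhibition), the three measured compounds sit close together: compound 3, at 78 nM, lies within the scatter of both compound 1 and compound 2. The next compound, compound 4 `Cc1cc2c(cc1C(=O)N=C(N)N)S(=O)(=O)CC2O`, differs from compound 3 in one place: hydroxy in place of ethyl on a saturated ring carbon. This puts hydroxy in place of ethyl on a saturated ring carbon, two ring bonds from the ring sulfur.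

For the measured compounds named here, one measured step bears directly on this change. The step of a 1.0-fold higher number from compound 1 to compound 3 (0.01 log units; within the scatter) swaps hydroxy for hydrogen while ethyl stays, and it lies within the scatter. Going by the values given here, no measured step removes ethyl alone, so that part of the change remains untested. Compound 2 also carries hydroxy without ethyl and gives 102 nM, but it has further methyl groups that compound 4 lacks.

A small move toward a higher number, meaning weaker inhibition, is therefore expected in this assay, with considerable uncertainty. The expected step is a 2.2-fold higher number from compound 3 to compound 4 (0.34 log units; beyond the scatter). For compound 4 the estimated value is 170 nM, with an expected range of 60 nM to 500 nM.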

Compound 4, half-maximal inhibitory concentration: 1050 nM
Beside the measured number, compound 4's estimate is 6.2-fold (0.79 log units) below it; the measured number lies above the stated range.
By their numbers in this assay, from the lowest: compounds 1, 3 and 2 (each within the scatter of the next); then compound 4.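

In this assay the change brings a 13-fold higher number from compound 3 to compound 4 (1.13 log units; beyond the scatter) when hydroxy takes the place of ethyl on a saturated ring carbon, two ring bonds from the ring sulfur, so this position does not accept the swap as a neutral one. The earlier compounds had shown only that hydroxy could be lost while ethyl stayed, with a 1.0-fold higher number from compound 1 to compound 3 (0.01 log units; within the scatter) and no change beyond the scatter, whereas keeping hydroxy and putting hydrogen in place of ethyl gives a 14-fold higher number from compound 1 to compound 4 (1.13 log units; beyond the scatter) and shows that, among these compounds, the large loss of inhibition goes with the loss of ethyl rather than with the presence or absence of hydroxy. Nothing measured here explains why ethyl matters at this carbon.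

The compounds shown leave open whether a longer chain such as propyl, or a ring such as cyclopropyl, would hold the number near that of compound 3 in this assay. They also leave open how an amine in place of ethyl on this carbon would compare with hydroxy, and what this carbon gives when it carries hydrogen alone.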